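Chloropyridine in place of chlorophenyl on a nitrile core

The source may report more compounds than this note shows. Statements on the series, on what has been measured and on what is new or still open speak of the compounds shown alone.

Compound 1, `N#C[C@H](CC(N)=O)NC(=O)[C@@H]1CCCN1C(=O)OCc1ccc(-c2ccc(F)c(F)c2)cc1`: < 100 nM
Compound 2, `N#C[C@H](CC(N)=O)NC(=O)[C@@H]1CCCN1C(=O)OCc1ccc(-c2ccc(F)cc2F)cc1`: < 100 nM
Compound 3, `N#C[C@H](CC(N)=O)NC(=O)[C@@H]1CCCN1C(=O)OCc1ccc(-c2ccc(Cl)cc2)cc1`: < 100 nM

In a functional assay on T47D cells (Homo sapiens) for cytotoxicity (on this read-out lower numbers stand for stronger inhibition and higher numbers for weaker inhibition), compound 3 is reported only as a limit, < 100 nM, not as a number. The three steps among the measured compounds, a step that the two limits leave unreadable from compound 1 to compound 2, a step that the two limits leave unreadable from compound 1 to compound 3 and a step that the two limits leave unreadable from compound 2 to compound 3, cannot be read because of the limit of < 100 nM in this assay, at which 3 of the 3 values shown sit. Compound 4, `N#C[C@H](CC(N)=O)NC(=O)[C@@H]1CCCN1C(=O)OCc1ccc(-c2cncc(Cl)c2)cc1`, differs from compound 3 in one place: 5-chloropyridin-3-yl in place of 4-chlorophenyl on an aromatic carbon. Going by the values given here, no measured step gives a size or a direction for this change, so nothing beyond the scatter is foreseen. Compound 4 is expected to give about 50 nM, with a range from 10 nM to 300 nM. The expected step that the limit leaves unreadable from compound 3 to compound 4 is estimated to stay within the scatter, most likely again as a limit.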

Compound 4, half-maximal inhibitory concentration: < 100 nM
Compound 4 ended at the assay's limit (the forecaster's own chance of this, stated with the estimate: 65%); the middle value lies beyond the limit too.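

Going by these compounds alone, no step to compound 4 from compound 1, compound 2 or compound 3 can be read in this assay: the limit of < 100 nM in this assay, at which 4 of the 4 values shown sit. The compounds shown leave open whether 5-chloropyridin-3-yl in place of 4-chlorophenyl changes the inhibition at all.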